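Replacing Cyclohexylamino with Pyrrolidin-1-yl on the Aromatic Ring

The compounds below may be only part of what the source reports. "The series", "measured", "known", "first", "only" and "open" are said of these compounds alone.

Of the compounds shown here, three have been measured in a functional assay on HL-60 cells (Homo sapiens) for cytotoxicity, read by MTT assay, with a stated time of 48 h; on this read-out lower numbers stand for stronger inhibition and higher numbers for weaker inhibition. Compound 1 `CCN(CC)c1ccc(C(F)(F)F)cc1NC(=O)c1cccnc1` gives 71000 nM, compound 2 `O=C(Nc1cc(C(F)(F)F)ccc1NC1CCCCC1)c1cccnc1` gives 48300 nM, and compound 3 `O=C(Nc1cc(C(F)(F)F)ccc1NC1CCCCC1)c1ccccc1` gives 34900 nM. Compound 2 holds the second highest of the three numbers, standing nearest to compound 3 and furthest from compound 1, but neither step separates it from its neighbours: a 1.4-fold lower number from compound 2 to compound 3 (0.14 log units; within the scatter), and a 1.5-fold lower number from compound 1 to compound 2 (0.17 log units; within the scatter). No order among the three can be claimed.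

Compound 4 `O=C(Nc1cc(C(F)(F)F)ccc1N1CCCC1)c1cccnc1` has not yet been measured in this assay. It differs from compound 2 in one place: pyrrolidin-1-yl in place of cyclohexylamino on an aromatic carbon. The measured step that bears on this change is the one at the same aromatic carbon, where diethylamino gave way to cyclohexylamino, and it was a 1.5-fold lower number from compound 1 to compound 2 (0.17 log units; within the scatter). The change on the carbonyl side, a 1.4-fold lower number from compound 2 to compound 3 (0.14 log units; within the scatter), was likewise small. Since the amine at this position has already been varied once without moving the number beyond the scatter, a step of similar size is expected here, in no firm direction, and the step expected is a 1.2-fold higher number from compound 2 to compound 4 (0.09 log units; within the scatter). Compound 4 is therefore estimated at 60000 nM, with a range from 30000 nM to 120000 nM.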

Compound 4, half-maximal inhibitory concentration: "not active" (no number reported)
Compound 4 has no reported number here, so the estimate cannot be set against anything.
By their numbers in this assay, from the lowest: compounds 3, 2 and 1 (each within the scatter of the next, the first and the last beyond it).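

Among these compounds, compound 4 is reported in this assay as not active, with no number, so no step from compound 2 to compound 4 can be read. The compounds shown leave open how the pyrrolidin-1-yl compound would stand numerically against compounds 1, 2 and 3. No evidence at hand bears on this result.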